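This account rests on a few compounds, and the source may have more. Where it says the series, first, only, none or still open, it means among the compounds named here.

Working notes on the series. The compounds share one core and differ only in the aryl group attached to it. Compound 1 `N#Cc1ccccc1-c1cnc(C(=O)CCCCCCc2ccccc2)o1` gives 130 nM in an assay (Rattus norvegicus) for inhibition of Fatty-acid amide hydrolase 1 (Homo sapiens); on this read-out higher numbers stand for weaker inhibition and lower numbers for stronger inhibition. Compound 2 `Nc1cccc(-c2cnc(C(=O)CCCCCCc3ccccc3)o2)c1` gives 19 nM in this assay, and compound 3 `O=C(CCCCCCc1ccccc1)c1ncc(-c2cccc(O)c2)o1` gives 50 nM in this assay. Among the three measured compounds, compound 3 stands second highest; the steps of a 2.6-fold lower number from compound 1 to compound 3 (0.41 log units; beyond the scatter) and a 2.6-fold higher number from compound 2 to compound 3 (0.42 log units; beyond the scatter) set it apart from both neighbours, each beyond the scatter. Compound 4 `O=C(CCCCCCc1ccccc1)c1ncc(-c2ccc([N+](=O)[O-])cc2)o1` carries the change (4-nitrophenyl in place of 3-hydroxyphenyl on an aromatic carbon). Among the compounds with values here, no measured step introduces a nitro group, so the bearing steps are indirect: a 6.8-fold lower number from compound 1 to compound 2 (0.84 log units; beyond the scatter) and a 2.6-fold lower number from compound 1 to compound 3 (0.41 log units; beyond the scatter) show that the amino- and hydroxy-bearing phenyls give lower numbers in this assay than the 2-cyanophenyl of compound 1, which carries neither group. The 4-nitrophenyl of compound 4 likewise carries neither, so the number is expected to move back toward that of compound 1; for compound 4 the expected step is a 2.2-fold higher number from compound 3 to compound 4 (0.34 log units; beyond the scatter), upward and modest. The estimate for compound 4 in this assay is 110 nM, with a range from 40 nM to 300 nM.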

Compound 4, inhibition constant: 50 nM
The estimate for compound 4 lay 2.2-fold (0.34 log units) above the measured number; measured number inside the range.
By their numbers in this assay, from the lowest: compound 2; then compounds 3 and 4 (each within the scatter of the next); then compound 1.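

In this assay the 4-nitrophenyl on this aromatic carbon gives no change at the digits printed from compound 3 to compound 4 (within the scatter) and so carries neither amino nor hydroxy, which means the lower numbers of the amino- and hydroxy-bearing phenyls do not set them apart from every other aryl group here. The 3-aminophenyl and 2-cyanophenyl still stand apart from the 4-nitrophenyl, with a 2.6-fold higher number from compound 2 to compound 4 (0.42 log units; beyond the scatter) and with a 2.6-fold lower number from compound 1 to compound 4 (0.41 log units; beyond the scatter) in the opposite direction, so this single position spans a range that compound 4 does not extend. No supporting data bear on the reason for this result.

The aryl groups shown differ in both substituent and its place on the phenyl ring, so the contribution of each remains unseparated. An unsubstituted phenyl or a carboxylic acid on the phenyl would give a further reference point for this position.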